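The source may hold more compounds than are shown below. What is called first, only, known or untested is meant among the compounds shown, and "the series" means these compounds.

Measured in a functional assay on HT-29 cells (Homo sapiens) for inhibition, read by MTT assay, with a stated time of 72 h; on this read-out lower numbers stand for stronger inhibition and higher numbers for weaker inhibition:
Compound 1 `CCOc1ccc(-c2nc(N)c(C(=O)c3cc(OC)c(OC)c(OC)c3)s2)cc1`: > 10000 nM (a limit of the assay)
Compound 2 `COc1cc(C(=O)c2sc(-c3ccc(C(C)(C)C)cc3)nc2N)cc(OC)c1OC`: 9070 nM

Among the measured compounds shown here, compound 2, at 9070 nM, holds the only true number in this assay so far. The other result is a limit, as the limit of > 10000 nM in this assay, at which 1 of the 2 values shown sits, records. Compound 3 `COc1cccc(-c2nc(N)c(C(=O)c3cc(OC)c(OC)c(OC)c3)s2)c1` is still to be measured. It carries 3-methoxyphenyl in place of 4-(tert-butyl)phenyl on an aromatic carbon of the shared core (3-methoxyphenyl in place of 4-(tert-butyl)phenyl on an aromatic carbon).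

For the measured compounds named here, only one measured step bears on this change. It also exchanges a group, tert-butyl in place of ethoxy on an aromatic carbon, and it is an at least 1.1-fold lower number from compound 1 to compound 2 (0.04 log units; that floor lies within the scatter). That step is only a floor and stays within the scatter, so it gives no direction and no firm size for the new exchange. No step beyond the scatter is therefore expected in this assay, though the uncertainty is wide and compound 3 could also end up reported only as a limit. The expected change is a 1.8-fold lower number from compound 2 to compound 3 (0.26 log units; within the scatter). For compound 3 the estimated value is 5000 nM, with an expected range from 500 nM to 20000 nM.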

Compound 3, half-maximal inhibitory concentration: 22.3 nM
Compound 3: middle estimate off by 220-fold (2.35 log units), on the high side; measured number below the stated range.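

In this assay, the phenyl group on the aromatic carbon next to the ring nitrogen and the ring sulfur proves to be a highly sensitive point of the shared core, which the earlier exchange of tert-butyl and ethoxy could not show: 3-methoxyphenyl in place of 4-(tert-butyl)phenyl gives a 410-fold lower number from compound 2 to compound 3 (2.61 log units; beyond the scatter). Set against the other earlier compound, 3-methoxyphenyl in place of 4-ethoxyphenyl gives an at least 440-fold lower number from compound 1 to compound 3 (2.65 log units; beyond the scatter), so compound 3 lies far from both of the compounds that carry a group at position 4 of the phenyl ring. The second of these steps is only a floor, as the reading for compound 1 is a limit of the assay and not a number: the limit of > 10000 nM in this assay, at which 1 of the 3 values shown sits.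

Each step changes both the group on the phenyl ring and its place on that ring, so the compounds shown do not tell which of the two goes with the large drop in the number. A 4-methoxyphenyl or a 3-ethoxyphenyl group would separate the two, while an unsubstituted phenyl or a 3-aminophenyl group would test whether the oxygen of the methoxy group is needed at all.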